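Ring changes on the amide nitrogen: outlook for compound 3

This account rests on a few compounds, and the source may have more. Where it says the series, first, only, none or still open, it means among the compounds named here.

Measured so far in an assay on cell membranes for binding affinity to 2-oxoglutarate receptor 1 (Rattus norvegicus), read by radioligand binding; on this read-out higher numbers stand for weaker inhibition and lower numbers for stronger inhibition:
compound 1 `Nc1ncnc2c1ncn2[C@@H]1O[C@H](C(=O)NC2CCCC2)[C@@H](O)[C@H]1O`, 49 nM
compound 2 `Nc1ncnc2c1ncn2[C@@H]1O[C@H](C(=O)NC2CCCCC2)[C@@H](O)[C@H]1O`, 18 nM

Going by the values given here, compound 2 stands at the lowest of the two numbers; its only neighbour is compound 1, removed by a 2.7-fold lower number from compound 1 to compound 2 (0.43 log units; beyond the scatter). Compound 3 `C[C@H]1CC[C@H](NC(=O)[C@H]2O[C@@H](n3cnc4c(N)ncnc43)[C@H](O)[C@@H]2O)CC1` differs from compound 2 by methyl in place of hydrogen on a saturated ring carbon. Among the compounds with values here, the one measured step, a 2.7-fold lower number from compound 1 to compound 2 (0.43 log units; beyond the scatter), concerns the size of the ring on the amide nitrogen, not a substituent on that ring, so it bears only loosely here; no measured pair tests a methyl on the ring. The step is therefore expected to be small, a 1.2-fold lower number from compound 2 to compound 3 (0.08 log units; within the scatter), within the scatter. Compound 3 is estimated at 15 nM, range 5 nM to 45 nM.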

Compound 3, inhibition constant: 12.9 nM
Estimate against measurement, compound 3: 1.2-fold (0.07 log units) above, within the range that was stated.
By their numbers in this assay, from the lowest: compounds 3 and 2 (each within the scatter of the next); then compound 1.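

In this assay, methyl in place of hydrogen on a saturated ring carbon, three ring bonds from the ring atom that bears a large group, gives a 1.4-fold lower number from compound 2 to compound 3 (0.14 log units; within the scatter), so this position accepts the added carbon without a change beyond the scatter. With 4-methylcyclohexyl in place of cyclopentyl, the series shows a 3.8-fold lower number from compound 1 to compound 3 (0.58 log units; beyond the scatter), so the separation from compound 1 persists with the methyl present. No supporting data are available to explain either step. As far as these compounds go, whether a hydroxyl, an amine or a longer chain such as ethyl on that ring carbon would stay within the scatter of compound 2 remains open.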